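Moving from a tertiary amine to an amino acid head group

A few compounds are considered here, and "the series" means these few. Any claim that something is new, unique, unknown or untested is made for them only; others in the source may bear on it.

Measured compounds:
compound 1, `CCCCCCCCCCc1ccc(-c2noc(CCCN(C)C)n2)cc1`: 8%
compound 2, `CCCCCCCCCCc1ccc(-c2noc([C@@H]3CC[C@H](N)C3)n2)cc1`: 38%
compound 3, `CCCCCCCCCCc1ccc(-c2noc(-c3cccc(CN)c3)n2)cc1`: 2%

In an assay on HeLa cells for inhibition of sphingosine-1-phosphate transporter SPNS2 (Mus musculus), read by LC-MS, tested at 2 uM (a higher number here means more inhibition at the concentration tested (going by the name of the read-out), a lower number less inhibition), compound 1 gives 8%, the second highest of the three numbers. It sits close to compound 3, with a number 6 percentage points lower from compound 1 to compound 3 (within the scatter), and well below compound 2, with a number 30 percentage points higher from compound 1 to compound 2 (beyond the scatter). The unmeasured compound 4, `CCCCCCCCCCc1ccc(-c2noc(CC[C@@H](N)C(=O)O)n2)cc1`, differs from compound 1 by one change: amino(carboxy)methyl in place of (dimethylamino)methyl on a saturated chain carbon, two bonds along the chain from an aromatic carbon. Within the data shown here, two measured steps bear on it, both replacing the same dimethylamino-bearing group on the shared core. The step of a number 30 percentage points higher from compound 1 to compound 2 (beyond the scatter) shows that a primary amine on a small ring raised inhibition, whereas a number 6 percentage points lower from compound 1 to compound 3 (within the scatter) shows a primary amine on a phenyl group left it unchanged. Among the measured compounds shown here, compound 4 keeps a chain and adds a primary amine together with a carboxylic acid, for which no measured analogue exists. The author therefore expects a modest rise, a number 14 percentage points higher from compound 1 to compound 4 (beyond the scatter), with wide uncertainty. For compound 4 the estimate in this assay is 22%, within 0% to 55%.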

Compound 4, a percentage reported as inhibition, at one concentration (the size of the read-out at that concentration, not a potency): 5%
Compound 4: middle estimate off by 17 percentage points, on the high side, and the stated range covers the measured number.
By their numbers in this assay, from the lowest: compounds 3, 4 and 1 (each within the scatter of the next); then compound 2.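

In this assay, 3-amino-3-carboxypropyl in place of 3-(dimethylamino)propyl gives a number 3 percentage points lower from compound 1 to compound 4 (within the scatter), so a chain carrying a primary amine together with a carboxylic acid does not reach the level of the 3-aminocyclopentyl group, as a number 33 percentage points lower from compound 2 to compound 4 (beyond the scatter) shows. With a number 3 percentage points higher from compound 3 to compound 4 (within the scatter), the amino acid head group falls in one low group with the 3-(aminomethyl)phenyl and 3-(dimethylamino)propyl compounds, leaving compound 2 alone above the other three. Nothing given here accounts for this separation.

Going by these compounds, it remains open whether a plain 3-aminopropyl chain, with a primary amine and no carboxylic acid, would sit with compound 2 or with compound 4. On these data alone, it is equally open whether adding a carboxylic acid to the 3-aminocyclopentyl ring would keep the level of compound 2.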